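A few compounds are considered here, and "the series" means these few. Any claim that something is new, unique, unknown or untested is made for them only; others in the source may bear on it.

In a functional assay on K562 cells (Homo sapiens) for cytotoxicity, read by MTT assay (a higher number here means a weaker inhibitor, a lower number a stronger inhibitor), three compounds have been measured:
- compound 1 `C#CCOc1cc(/C=C/C(=O)c2ccc(OC)c3c2OC(C)(C)C=C3)ccc1OC`: > 10000 nM, a limit
- compound 2 `C=CCOc1cc(/C=C/C(=O)c2ccc(OC)c3c2OC(C)(C)C=C3)ccc1OC`: > 10000 nM, a limit
- compound 3 `COc1ccc(/C=C/C(=O)c2ccc(OC)c3c2OC(C)(C)C=C3)cc1OCCO`: 8750 nM

Within the data shown here, compound 3 holds the only true number here, 8750 nM. The other two sit at the limit of > 10000 nM in this assay, at which 2 of the 3 values shown sit.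

Compound 4 `COc1ccc(/C=C/C(=O)c2ccc(OC)c3c2OC(C)(C)C=C3)cc1OCCCN(C)C` carries 3-(dimethylamino)propoxy in place of 2-hydroxyethoxy: (dimethylamino)methyl in place of hydroxy on a saturated chain carbon, two bonds along the chain from an oxygen on an aromatic ring.

Two measured steps changed this same chain: an at least 1.1-fold lower number from compound 1 to compound 3 (0.05 log units; that floor lies within the scatter) and an at least 1.1-fold lower number from compound 2 to compound 3 (0.05 log units; that floor lies within the scatter). Both are only floors, so they fix no firm size. On that thin basis, only a small move is expected in this assay, none clearly beyond the scatter, and the expected change is a 1.5-fold lower number from compound 3 to compound 4 (0.16 log units; within the scatter). For compound 4 the estimated value is 6000 nM, with an expected range from 2000 nM to 12000 nM.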

Compound 4, half-maximal inhibitory concentration: 2920 nM
Compound 4: middle estimate off by 2.1-fold (0.31 log units), on the high side; low and high end bracket the measured number.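

In this assay, this chain position now gives a step that clears the scatter: a 3.0-fold lower number from compound 3 to compound 4 (0.48 log units; beyond the scatter). The earlier compounds shown here showed only floors within the scatter here, whereas the 3-(dimethylamino)propoxy chain also gives an at least 3.4-fold lower number from compound 2 to compound 4 (0.53 log units; beyond the scatter) and an at least 3.4-fold lower number from compound 1 to compound 4 (0.53 log units; beyond the scatter). These two are floors as well, since compounds 1 and 2 each sit at a limit: the limit of > 10000 nM in this assay, at which 2 of the 4 values shown sit.

Going by these compounds, whether the nitrogen or the longer chain carries this step stays open, and a 3-hydroxypropoxy chain would bear on that. On these data alone, how a shorter 2-(dimethylamino)ethoxy chain or a ring amine such as morpholine would fare at this position also stays open.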